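Methyl to Fluoro Swap in a Cell Growth Assay

This account rests on a few compounds, and the source may have more. Where it says the series, first, only, none or still open, it means among the compounds named here.

Measured so far:
- compound 1, `COc1ccc(/C=C/c2ccc(F)cc2)cc1`: 156 ug/mL
- compound 2, `COc1ccc(/C=C/c2ccc(C)cc2)cc1`: a limit, > 200 ug/mL
- compound 3, `Cc1ccc(/C=C/c2ccccc2F)cc1`: 78 ug/mL

In a functional assay on CCRF-CEM cells (Homo sapiens), read by cell counting, with a stated time of 72 h (a lower number here means a stronger inhibitor, a higher number a weaker inhibitor), compound 1 gives 156 ug/mL. Compound 2 reaches only a limit of the assay, > 200 ug/mL. Compound 3 gives 78 ug/mL. Within the data shown here, the one measured change, (fluoro in place of methyl on an aromatic carbon), made a step of an at least 1.2-fold lower number from compound 2 to compound 1 (0.10 log units; that floor lies within the scatter); that step is only a floor because the limit of > 200 ug/mL in this assay, at which 1 of the 3 values shown sits, leaves the true value of compound 2 unknown. How the core of compound 3 differs from that of compound 2 is not broken down here.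

Compound 4, `Fc1ccc(/C=C/c2ccccc2F)cc1`, is not yet measured. It arises from compound 3 by fluoro in place of methyl on an aromatic carbon. This is the same kind of change as in compound 1, though one place is described as para to a group of 9 heavy atoms and the other as para to a large group. Beside an at least 1.2-fold lower number from compound 2 to compound 1 (0.10 log units; that floor lies within the scatter), the expected step is a 1.3-fold lower number from compound 3 to compound 4 (0.11 log units; within the scatter), resting on that floor. Compound 4 is therefore estimated at 60 ug/mL, with a likely range of 30 ug/mL to 120 ug/mL.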

Compound 4, half-maximal inhibitory concentration: 83 ug/mL
Compound 4: the middle estimate sits 1.4-fold (0.14 log units) below what was measured, within the range that was stated.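

In this assay, fluoro in place of methyl on an aromatic carbon gives a 1.1-fold higher number from compound 3 to compound 4 (0.03 log units; within the scatter), so on the core of compound 3 the two numbers cannot be told apart from ordinary repeat-to-repeat variation. Set beside the same swap on the other core, the comparison reads: the same change on two cores in this assay, an at least 1.2-fold lower number (0.10 log units; that floor lies within the scatter) from compound 2 to compound 1 and a 1.1-fold higher number (0.03 log units; within the scatter) from compound 3 to compound 4; the limit leaves it open whether they differ. Compound 2 stands at a limit rather than at a true number, so these two cases neither show that the swap carries over unchanged from one core to the other nor show that it fails to carry over: the limit of > 200 ug/mL in this assay, at which 1 of the 4 values shown sits.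

From the compounds shown here alone, only methyl and fluoro are compared at this place, so it remains open whether a chloro, a hydroxyl or an amine on the same aromatic carbon would move the number in this assay. Going by these compounds, it is also open whether any replacement there can give a step beyond the scatter on either core.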